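The compounds below may be only part of what the source reports. "The series", "measured", "known", "first", "only" and "open" are said of these compounds alone.

Working notes on the series.

Compound 1 `C=C1[C@@H](OC(C)=O)C[C@@H]2[C@](C)(COC=O)[C@H](OC(C)=O)CC[C@@]2(C)[C@@H]1C/C=C1/C(=O)OC[C@H]1OC(C)=O` and compound 2 `C=C1[C@@H](OC(C)=O)C[C@@H]2[C@](C)(CO[Si](C)(C)C(C)(C)C)[C@H](OC(C)=O)CC[C@@]2(C)[C@@H]1C/C=C1/C(=O)OC[C@H]1OC(C)=O` share a core and differ at one point: a group of 7 heavy atoms (6 carbon, 1 silicon; no ring) in place of a group of 2 heavy atoms (1 carbon, 1 oxygen; no ring), on an oxygen on a saturated carbon. In a functional assay on MCF7 cells (Homo sapiens) for cytotoxicity, read by sulforhodamine B assay (a higher number here means a weaker inhibitor, a lower number a stronger inhibitor), compound 1 gives 12900 nM, and compound 2 gives 4540 nM. For the measured compounds named here, the step between them, a 2.8-fold lower number from compound 1 to compound 2 (0.45 log units; beyond the scatter), is the only measured instance of this change so far.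

Compound 3 `C=C1[C@@H](OC(C)=O)C[C@@H]2[C@](C)(COC=O)[C@H](OC(C)=O)CC[C@@]2(C)[C@@H]1C[C@@H](Nc1ccccc1)C1=CCOC1=O` carries a different core from compound 1; the difference between the two cores is not broken down here. In this assay compound 3 gives 26200 nM, the highest number of the three measured compounds, with compound 1 nearest and compound 2 furthest.

Compound 4 `C=C1[C@@H](OC(C)=O)C[C@@H]2[C@](C)(CO[Si](C)(C)C(C)(C)C)[C@H](OC(C)=O)CC[C@@]2(C)[C@@H]1C[C@@H](Nc1ccccc1)C1=CCOC1=O` is not yet measured. It stands to compound 3 as compound 2 stands to compound 1: a group of 7 heavy atoms (6 carbon, 1 silicon; no ring) in place of a group of 2 heavy atoms (1 carbon, 1 oxygen; no ring), on an oxygen on a saturated carbon. The place of the change reads the same in both pairs, so this is the same change made on a different core.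

The expectation for compound 4 in this assay rests on one precedent only, the step of a 2.8-fold lower number from compound 1 to compound 2 (0.45 log units; beyond the scatter) on the core of compound 1, and assumes the change carries over to the core of compound 3 with no other support than that. On that basis the step from compound 3 is expected to be a 2.8-fold lower number from compound 3 to compound 4 (0.44 log units; beyond the scatter). The number expected for compound 4 is therefore 9500 nM, with the plausible range estimated from 4000 nM to 22000 nM.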

Compound 4, half-maximal inhibitory concentration: 4840 nM
Compound 4: the middle estimate sits 2.0-fold (0.29 log units) above what was measured; low and high end bracket the measured number.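

In this assay, exchanging the formyl group for the group of 7 heavy atoms, on an oxygen on a saturated carbon, gives a 5.4-fold lower number from compound 3 to compound 4 (0.73 log units; beyond the scatter), the same direction as on the core of compound 1. The two steps cannot be told apart in size: the same change on two cores in this assay, a 2.8-fold lower number (0.45 log units; beyond the scatter) from compound 1 to compound 2 and a 5.4-fold lower number (0.73 log units; beyond the scatter) from compound 3 to compound 4, 1.9-fold (0.28 log units) apart, within the scatter of two such steps. This shows that the change carried over from the core of compound 1 to the core of compound 3 in direction and, within the scatter, in size, but two pairs do not show that it would carry over to any further core, that the larger printed step on the core of compound 3 is real, or why the number falls on either core.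

The compounds shown leave open whether a free hydroxyl, a benzyl group or a longer alkyl chain on that same oxygen would move the number in this assay in the same way, and so which feature of the group of 7 heavy atoms goes with the lower number. Also open, going by these compounds, is whether the same step would appear on a core carrying an aliphatic amine in place of the phenylamino group of compound 3.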